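Swapping Fluoro for Chloro in a Growth Inhibitor

A few compounds are considered here, and "the series" means these few. Any claim that something is new, unique, unknown or untested is made for them only; others in the source may bear on it.

Compound 1 `Cc1ccnc2nc(-c3cccc(Cl)c3)cc(O)c12` gives 52.5 nM
Compound 2 `Cc1ccc2c(O)cc(-c3cccc(Cl)c3)nc2n1` gives 64.6 nM
Compound 3 `Cc1cc(C)c2c(O)cc(-c3cccc(F)c3)nc2n1` gives 64.6 nM

These three values come from a functional assay on U-251 cells (Homo sapiens) for antiproliferative activity; a higher number here means a weaker inhibitor of growth, a lower number a stronger inhibitor of growth. Compound 3 gives 64.6 nM and so stands level with compound 2, and all three compounds lie within the usual scatter of one another.

The next compound to be tested, compound 4 `Cc1cc(C)c2c(O)cc(-c3cccc(Cl)c3)nc2n1`, differs from compound 3 in a single place: chloro in place of fluoro on an aromatic carbon. Among the measured compounds shown here, no measured pair shows this change on its own, so its size cannot be read directly from the data. There is only indirect evidence. Compound 1 also carries chloro and gives 52.5 nM in this assay, and compound 2 also carries chloro and gives 64.6 nM there. Both sit within the scatter of compound 3, so no shift beyond the scatter is expected. The estimated step of a 1.2-fold lower number from compound 3 to compound 4 (0.06 log units; within the scatter) is accordingly small. For compound 4 the expected value is 56 nM (estimated range 26 nM to 120 nM).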

Compound 4, concentration for 50% growth inhibition: 295 nM
Compound 4: the middle estimate sits 5.3-fold (0.72 log units) below what was measured; the whole stated range lies below it.
By their numbers in this assay, from the lowest: compounds 1, 2 and 3 (each within the scatter of the next); then compound 4.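

In this assay, chloro in place of fluoro on this aromatic carbon turns out not to be a neutral swap on the core of compound 3, giving a clear loss of growth inhibition (a 4.6-fold higher number from compound 3 to compound 4 (0.66 log units; beyond the scatter)). Methyl in place of hydrogen on an aromatic carbon gives a similar loss when chloro is already present (a 4.6-fold higher number from compound 2 to compound 4 (0.66 log units; beyond the scatter); a 5.6-fold higher number from compound 1 to compound 4 (0.75 log units; beyond the scatter)), so among these four compounds, chloro and the added methyl raise the number only when they occur together. Nothing measured here explains why this combination behaves differently.

The compounds shown leave open how fluoro would behave on the cores of compound 1 and compound 2, which would test this dependence directly. They also leave open whether a larger group at the same position, such as bromo or methoxy, would follow chloro.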